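Amine Substituent Exchange on a Diether Scaffold

The source may hold more compounds than are shown below. What is called first, only, known or untested is meant among the compounds shown, and "the series" means these compounds.

Three compounds have been measured in a functional assay on SK-OV-3 cells (Homo sapiens) for inhibition, read by CCK-8 assay, with a stated time of 70 h; on this read-out lower numbers stand for stronger inhibition and higher numbers for weaker inhibition:

compound 1 `c1ccc(COc2ccc(OCCOCCNc3ccccc3)cc2)cc1`: > 100000 nM
compound 2 `c1ccc(COc2ccc(OCCOCCNc3cc[nH]c3)cc2)cc1`: 11300 nM
compound 3 `c1ccc(COc2ccc(OCCOCCNC3CCOC3)cc2)cc1`: 48000 nM

The value of compound 1 is a limit of the assay, not a number (the limit of > 100000 nM in this assay, at which 1 of the 3 values shown sits). Of the two numbers shown, compound 3 sits highest; its nearest neighbour is compound 2, with a 4.2-fold higher number from compound 2 to compound 3 (0.63 log units; beyond the scatter). Compound 4 `c1ccc(COc2ccc(OCCOCCNC3CCCCC3)cc2)cc1` differs from compound 3 by cyclohexyl in place of oxolan-3-yl on an amine nitrogen. Among the compounds with values here, no measured step exchanges one saturated ring for another: an at least 8.8-fold lower number from compound 1 to compound 2 (0.94 log units; beyond the scatter) and an at least 2.0-fold lower number from compound 1 to compound 3 (0.31 log units; beyond the scatter) both start from the phenyl of compound 1, and the closest comparison remains a 4.2-fold higher number from compound 2 to compound 3 (0.63 log units; beyond the scatter). The data give no direction for this exchange, so for compound 4 a step of a 1.3-fold higher number from compound 3 to compound 4 (0.10 log units; within the scatter) is expected, within the scatter or slightly weaker. Compound 4 is therefore estimated at 60000 nM, ranging from 20000 nM to 200000 nM.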

Compound 4, half-maximal inhibitory concentration: 7370 nM
Beside the measured number, compound 4's estimate is 8.1-fold (0.91 log units) above it; the measured number lies below the stated range.
By their numbers in this assay, from the lowest: compounds 4 and 2 (each within the scatter of the next); then compound 3. At a limit, above all of these: compound 1.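

Exchanging one saturated ring for another on the amine nitrogen clearly moves the result in this assay: cyclohexyl in place of oxolan-3-yl gives a 6.5-fold lower number from compound 3 to compound 4 (0.81 log units; beyond the scatter). Cyclohexyl and 1H-pyrrol-3-yl stay within the scatter of each other, with a 1.5-fold lower number from compound 2 to compound 4 (0.19 log units; within the scatter), whereas replacing phenyl gives an at least 13-fold lower number from compound 1 to compound 4 (1.13 log units; beyond the scatter). That last step starts from compound 1, whose value is a limit of the assay: the limit of > 100000 nM in this assay, at which 1 of the 4 values shown sits.

As far as these compounds go, it remains open whether ring size or the ring oxygen separates compound 3 from compound 4. Cyclopentyl or oxan-4-yl on the same amine nitrogen would separate the two.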